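The source may report more compounds than this note shows. Statements on the series, on what has been measured and on what is new or still open speak of the compounds shown alone.

The compounds measured so far, with their values:

Compound 1, `CC1CC/C(=N\Nc2ccc(F)cc2)c2ncc(C(=O)O)c(=O)n21`, in a functional assay on the whole organism for inhibition, with Rattus norvegicus as the target (a higher number here means that more compound is needed for the effect, a lower number that less compound is needed), gives 12.2 umol/kg.
Compound 2, `CC1CC/C(=N\Nc2ccc(Cl)cc2)c2ncc(C(=O)O)c(=O)n21`, in this assay gives 0.5 umol/kg.
Compound 3, `CC1CC/C(=N\Nc2ccc(O)cc2)c2ncc(C(=O)O)c(=O)n21`, in this assay gives 1.7 umol/kg.

Compound 3 stands second highest of the three numbers. Its nearest neighbour is compound 2, the step being a 3.4-fold higher number from compound 2 to compound 3 (0.53 log units; beyond the scatter), and its furthest is compound 1, the step being a 7.2-fold lower number from compound 1 to compound 3 (0.86 log units; beyond the scatter). The largest step in the set is a 24-fold lower number from compound 1 to compound 2 (1.39 log units; beyond the scatter).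

Compound 4, `C[C@@H]1CC/C(=N\Nc2ccc(O)cc2)c2ncc(C(=O)O)c(=O)n21`, differs from compound 3 only in stereochemistry: the two compounds have the same atoms and bonds; at least one stereo element is drawn with a configuration in one of them and without one in the other: 1 of 2 stereo elements differ; a stereocentre at a saturated ring carbon is drawn without a configuration in compound 3 and R in compound 4.

None of the three measured steps bears directly on this change; each of them swaps the group on the aromatic carbon and leaves the saturated ring carbon untouched. With no stereochemical comparison available, the account has nothing to set a direction. Compound 4 is therefore expected to give a step of a 1.4-fold lower number from compound 3 to compound 4 (0.15 log units; within the scatter), one that need not be beyond the scatter. The value of compound 4 in this assay is estimated at 1.2 umol/kg, with a range from 0.5 umol/kg to 4 umol/kg.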

Compound 4, dose for 50% inhibition: 0.14 umol/kg
Estimate against measurement, compound 4: 8.6-fold (0.93 log units) above, and the stated range ends above it.
By their numbers in this assay, from the lowest: compound 4; then compound 2; then compound 3; then compound 1.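

Every earlier step in this assay swapped the group on the aromatic carbon, so they showed nothing about the saturated ring carbon; this one shows that this carbon matters too. With the hydroxy group and all other atoms and bonds left as they are, defining the stereocentre as R goes with a 12-fold lower number from compound 3 to compound 4 (1.08 log units; beyond the scatter), which is a large step for a change that alters no atom or bond. The only difference that can be pointed to for this step is the one in how the two structures are drawn: the fact that one of compounds 3 and 4 is drawn with a defined configuration and the other without, at the place where they differ

The compounds shown do not tell what compound 3 contains at that carbon, nor how the S configuration would read in this assay, so the step cannot yet be divided between the presence of the R form and the absence of any other form. Also open, from the compounds shown here alone, is whether the same stereochemical step would appear with the chloro or fluoro group on the aromatic carbon, and what an ethyl or hydroxymethyl group at the saturated ring carbon would do.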